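Pyridin-4-yl for Phenyl in the Ether Arm of Compound 3

A few compounds are considered here, and "the series" means these few. Any claim that something is new, unique, unknown or untested is made for them only; others in the source may bear on it.

Measured compounds, with their results in a functional assay on HEK293 cells for positive allosteric modulation of metabotropic glutamate receptor 5 (Homo sapiens), read by FLIPR and calcium flux; a higher number here means that more compound is needed for the effect, a lower number that less compound is needed:
compound 1 `O=C(COCc1ccccc1)N1CCN(c2ccc(F)cc2)CC1` gives 1100 nM
compound 2 `O=C(COCc1ccccc1)N1CCN(c2ccc(Cl)cc2Cl)CC1` gives 1000 nM
compound 3 `O=C(COCc1ccccc1)N1CCN(c2ccc(F)cc2F)CC1` gives 300 nM

Compound 3 stands lowest of the three: the change was a 3.3-fold lower number from compound 2 to compound 3 (0.52 log units; beyond the scatter) and a 3.7-fold lower number from compound 1 to compound 3 (0.56 log units; beyond the scatter), both beyond the scatter, whereas a 1.1-fold lower number from compound 1 to compound 2 (0.04 log units; within the scatter) lies within it. Compound 4 `O=C(COCc1ccncc1)N1CCN(c2ccc(F)cc2F)CC1` differs from compound 3 by pyridin-4-yl in place of phenyl on a saturated chain carbon bound to an oxygen on a saturated carbon. Among the measured compounds shown here, none of the measured steps touches this arm; all three varied only the aryl group on the amine nitrogen in a ring, so no measured step bears directly on the change, and the expectation rests on compound 3 alone. Compound 4 is therefore expected to show no step beyond the scatter in this assay, with wide uncertainty. The expected step is a 1.3-fold higher number from compound 3 to compound 4 (0.12 log units; within the scatter). Compound 4 is estimated at 400 nM, within 120 nM to 1500 nM.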

Compound 4, half-maximal effective concentration: 4600 nM
The estimate for compound 4 lay 12-fold (1.06 log units) below the measured number; measured number outside the range, above it.
By their numbers in this assay, from the lowest: compound 3; then compounds 2 and 1 (each within the scatter of the next); then compound 4.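

The ether arm, which no earlier step touched, turns out to matter in this assay: pyridin-4-yl in place of phenyl gives a 15-fold higher number from compound 3 to compound 4 (1.19 log units; beyond the scatter) and is the only large step shown, whereas the steps among the aryl groups on the amine nitrogen are modest at most. The two groups have the same heavy-atom count, and the one that enters carries one ring nitrogen and one hydrogen-bond acceptor. Nothing at hand explains the rise. As far as these compounds go, whether cyclohexyl or thienyl in this arm would keep the number of compound 3 stays open, as does whether pyridin-4-yl has the same effect alongside the 2,4-dichlorophenyl group of compound 2.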